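This account rests on a few compounds, and the source may have more. Where it says the series, first, only, none or still open, it means among the compounds named here.

Compound 1 `CN(C)CCNc1nc(-c2ccc(NC(=O)Nc3ccc(F)cc3)cc2)nc2c(Cl)c(Cl)sc12` in a functional assay on MDA-MB-231 cells (Homo sapiens) for cytotoxicity, read by MTT assay, with a stated time of 72 h (on this read-out higher numbers stand for weaker inhibition and lower numbers for stronger inhibition), gives 1240 nM. Compound 2 `CN(C)CCNc1nc(-c2ccc(NC(=O)Nc3ccccc3Cl)cc2)nc2c(Cl)c(Cl)sc12` in this assay gives 1350 nM; the step of a 1.1-fold higher number from compound 1 to compound 2 (0.04 log units; within the scatter) exchanges the aryl on the urea nitrogen and stays within the scatter, so on these two numbers compound 1 and compound 2 are not separated, and compound 1 is simply the reference point for what follows. Compound 3 `CCN(CC)CCNc1nc(-c2ccc(NC(=O)Nc3ccc(F)cc3)cc2)nc2c(Cl)c(Cl)sc12` carries diethylamino in place of dimethylamino on a saturated chain carbon, two bonds along the chain from a nitrogen on an aromatic ring. Within the data shown here, no measured step touches this part of the shared core: the only step in hand, a 1.1-fold higher number from compound 1 to compound 2 (0.04 log units; within the scatter), concerns the urea aryl and says nothing about the dimethylamino on the saturated chain carbon. With nothing to build on, the expectation for compound 3 in this assay is a number close to that of compound 1, a step of a 1.0-fold higher number from compound 1 to compound 3 (0.02 log units; within the scatter) not expected to go beyond the scatter in either direction. The estimate for compound 3 is 1300 nM, with a range of 500 nM to 3500 nM.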

Compound 3, half-maximal inhibitory concentration: 1130 nM
Estimate against measurement, compound 3: 1.2-fold (0.06 log units) above; the measured number falls inside the stated range.
By their numbers in this assay, from the lowest: compounds 3, 1 and 2 (each within the scatter of the next).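

In this assay, among these compounds, this is the first measured change at the amine end of the chain: diethylamino in place of dimethylamino on a saturated chain carbon, two bonds along the chain from a nitrogen on an aromatic ring, gives a 1.1-fold lower number from compound 1 to compound 3 (0.04 log units; within the scatter) and so leaves compound 1 and compound 3 unseparated. The series therefore now has a read on this position as well as on the urea aryl, and at this position the exchange of the two dialkylamino groups does not move the number beyond the scatter. No supporting measurement bears on this result.

Still open, as far as these compounds go, is whether the same holds for a ring amine such as morpholine or pyrrolidine in place of dimethylamino, or for a longer chain such as 3-(dimethylamino)propyl. Also open, from the compounds shown here alone, is whether diethylamino gives a similar number alongside the 2-chlorophenyl urea of compound 2.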